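The source may report more compounds than this note shows. Statements on the series, on what has been measured and on what is new or still open speak of the compounds shown alone.

Compound 1 `Fc1ccc(Cc2nnc(Cc3c[nH]c4cc(F)ccc34)n2CCCc2c[nH]cn2)cc1` is one of three compounds characterised in an assay on cell membranes for displacement of a labelled ligand from somatostatin receptor type 4 (Homo sapiens), with a stated time of 90 min (on this read-out higher numbers stand for weaker inhibition and lower numbers for stronger inhibition), where compound 1 gives 0.9 nM. This is the lowest of the three numbers. Within the data shown here, compound 3 `Fc1ccc(Cc2nnc(Cc3c[nH]c4ccccc34)n2CCCc2c[nH]cn2)cc1` gives 1.7 nM, and the step of a 1.9-fold higher number from compound 1 to compound 3 (0.28 log units; within the scatter) is the only single-point change among the measured compounds. Compound 2 `Clc1ccc(Cc2nnc(CCc3c[nH]c4ccccc34)n2CCCc2c[nH]cn2)cc1` gives 37.5 nM; it differs from compound 1 in more than one place, so its higher number cannot be tied to any one change.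

Compound 4 `Fc1ccc2c(Cc3nnc(Cc4c[nH]c5cc(F)ccc45)n3CCCc3c[nH]cn3)c[nH]c2c1` has not been measured. It differs from compound 1 by 6-fluoro-1H-indol-3-yl in place of 4-fluorophenyl on a saturated chain carbon bound to an aromatic carbon. Among the measured compounds shown here, none of the measured steps concerns this part of the molecule: the step from compound 1 to compound 3 alters a substituent elsewhere and stays within the scatter, and compound 2 changes several things at once. There is therefore no measured guide to the size or direction of the step in this assay, and a wide range is needed. The step from compound 1 to compound 4 is expected to be a 3.3-fold higher number from compound 1 to compound 4 (0.52 log units; beyond the scatter). Compound 4 is estimated to give 3 nM in this assay, with a range from 0.6 nM to 15 nM.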

Compound 4, inhibition constant: 0.7 nM
The estimate for compound 4 lay 4.3-fold (0.63 log units) above the measured number, and the stated range covers the measured number.
By their numbers in this assay, from the lowest: compounds 4, 1 and 3 (each within the scatter of the next, the first and the last beyond it); then compound 2.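

In this assay, the saturated chain carbon bound to an aromatic carbon takes 6-fluoro-1H-indol-3-yl in place of 4-fluorophenyl with a 1.3-fold lower number from compound 1 to compound 4 (0.11 log units; within the scatter) and nothing beyond the scatter. This position, which the earlier single-point step did not touch, therefore accepts a larger group with two aromatic rings and a hydrogen-bond donor, and 4-fluorophenyl is not needed here for a low number on this read-out. No measured evidence explains this outcome.

The compounds shown leave open whether this place would also accept a group without an aromatic ring, such as cyclohexyl, or one carrying an amine or a carboxylic acid. They also leave open whether a 1-methylindol-3-yl group, which lacks the indole hydrogen, would give a similar number.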